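The source may report more compounds than this note shows. Statements on the series, on what has been measured and on what is new or still open speak of the compounds shown alone.

The measured compounds:

compound 1, `O=C(CI)NCCCCNc1ncnc2c1ncn2[C@@H]1O[C@H](COP(=O)(O)OP(=O)(O)OP(=O)(O)O)[C@@H](O)[C@H]1O`, gives 0% in an assay on isolated protein for inhibition of hexokinase-2 (Rattus norvegicus), with a stated time of 6 h, tested at 10 mM; a higher number here means more inhibition at the concentration tested (going by the name of the read-out), a lower number less inhibition.
compound 2, `O=C(CI)NCCC(=O)NCCCCCCNc1ncnc2c1ncn2[C@@H]1O[C@H](COP(=O)(O)OP(=O)(O)OP(=O)(O)O)[C@@H](O)[C@H]1O`, gives 0% in this assay.
compound 3, `O=C(CI)NCCNc1ncnc2c1ncn2[C@@H]1O[C@H](COP(=O)(O)OP(=O)(O)OP(=O)(O)O)[C@@H](O)[C@H]1O`, gives 0% in this assay.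

Compound 3 stands level with compounds 1 and 2 in this assay; none of the three is set apart from the others. The two steps measured so far both change the group that sits on the chain carbon away from the aromatic nitrogen: no change at the digits printed from compound 1 to compound 2 (within the scatter), and no change at the digits printed from compound 1 to compound 3 (within the scatter). Neither moved the read-out.

Compound 4, `O=C(CI)NCCCCCCCNc1ncnc2c1ncn2[C@@H]1O[C@H](COP(=O)(O)OP(=O)(O)OP(=O)(O)O)[C@@H](O)[C@H]1O`, differs from compound 3 in the same way: 5-(((iodomethyl)carbonyl)amino)pentyl in place of ((iodomethyl)carbonyl)amino on a saturated chain carbon, two bonds along the chain from a nitrogen on an aromatic ring. Both measured steps bear directly on this change, since each swaps one such group for another of the same kind, and both were flat within the scatter. The expectation for compound 4 in this assay is therefore no step beyond the scatter, a number 1 percentage points higher from compound 3 to compound 4 (within the scatter). Compound 4 is estimated at 1% in this assay, expected to fall between 0% and 11%.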

Compound 4, a percentage reported as inhibition, at one concentration (the size of the read-out at that concentration, not a potency): 30%
Beside the measured number, compound 4's estimate is 29 percentage points below it; the whole stated range lies below it.
By their numbers in this assay, from the lowest: compounds 1, 2 and 3 (each within the scatter of the next); then compound 4.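

Within the data shown here, this is the first change at this position to move the read-out in this assay: replacing ((iodomethyl)carbonyl)amino with 5-(((iodomethyl)carbonyl)amino)pentyl gives a number 30 percentage points higher from compound 3 to compound 4 (beyond the scatter), whereas the earlier steps were flat. The 3-(((iodomethyl)carbonyl)amino)propyl group in place of ((iodomethyl)carbonyl)amino gives a number 30 percentage points higher from compound 1 to compound 4 (beyond the scatter), so the all-carbon chain of compound 4 is set apart from the shorter chains of compounds 1 and 3. Chain extent alone does not account for the pattern, since compound 2 goes against it: its long chain holds a further nitrogen and oxygen, and the step to the unbroken chain is a number 30 percentage points higher from compound 2 to compound 4 (beyond the scatter).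

On these data alone, whether a longer chain, such as a decyl linker, would raise the number further remains open, as does whether a chloromethyl carbonyl group could stand in for the iodomethyl carbonyl group. No evidence at hand accounts for the rise.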